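Thiazole ethers: chloro to methyl beside the enone

The compounds below may be only part of what the source reports. "The series", "measured", "known", "first", "only" and "open" are said of these compounds alone.

Compound 2 `C=C(C)C(=O)c1ccc(OCc2nc(-c3ccccc3)cs2)cc1Cl` gives 100% in an assay on HL-60 cells for inhibition of glutathione S-transferase P (Homo sapiens), read by spectrophotometry, tested at 5 uM (on this read-out higher numbers stand for more inhibition at the one concentration tested (going by the name of the read-out) and lower numbers for less inhibition), level with compound 1 `C=C(C)C(=O)c1ccc(OCc2nc(-c3ccccc3)cs2)c(C)c1C`, which gives 100% in this assay, no change at the digits shown. Compound 3 `C=C(C)C(=O)c1ccc(OCc2nc(-c3ccccc3)cs2)cc1C` differs from compound 2 by methyl in place of chloro on an aromatic carbon. Among the measured compounds shown here, no step between measured compounds is at hand for this change; compound 1, carrying a methyl at the same place, shows the read-out cannot go higher, so no step beyond the scatter is expected in either direction. Compound 3 is expected to give about 98% in this assay, between 85% and 100%, a step of a number 2 percentage points lower from compound 2 to compound 3 (within the scatter).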

Compound 3, a percentage reported as inhibition, at one concentration (the size of the read-out at that concentration, not a potency): 100%
Compound 3: middle estimate off by 2 percentage points, on the low side, within the range that was stated.
By their numbers in this assay, from the lowest: compounds 1, 2 and 3 (each within the scatter of the next).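

In this assay the step of no change at the digits printed from compound 2 to compound 3 (within the scatter) for methyl in place of chloro, ortho to a (1-methylethenyl)carbonyl group, and the step of no change at the digits printed from compound 1 to compound 3 (within the scatter) for hydrogen in place of methyl on an aromatic carbon leave the read-out unmoved. At this one concentration, with all three compounds at the top of the scale, neither change separates the compounds, and no stronger or weaker effect at this concentration can be read for any of them. Nothing at hand explains this result. Open, going by these compounds, is whether an amine or a carboxylic acid at this place would lower the read-out. Also open, on these data alone, is whether removing the methyl altogether, leaving hydrogen there, would do so.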